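Amide nitrogen substituent exchange in the shared core series

A few compounds are considered here, and "the series" means these few. Any claim that something is new, unique, unknown or untested is made for them only; others in the source may bear on it.

Measured compounds:
- compound 1 `CCn1c(C(=O)On2nnc3ccccc32)ccc1C(CC)(CC)c1ccc(C#CC(O)(CC)CC)c(C)c1`: in a functional assay on PC-3 cells (Homo sapiens) for antiproliferative activity, read by MTT assay, with a stated time of 72 h (a lower number here means a stronger inhibitor, a higher number a weaker inhibitor), compound 1 gives > 50000 nM, which is a limit of the assay and not a number.
- compound 2 `CCCCC(=O)c1ccc(C(CC)(CC)c2ccc(C#CC(O)(CC)CC)c(C)c2)n1CC`: compound 2 gives > 50000 nM, again a limit of the assay.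
- compound 3 `CCN(CC)CCNC(=O)c1cc(C(CC)(CC)c2ccc(C#CC(O)(CC)CC)c(C)c2)cn1CC`: compound 3 gives 5350 nM.

Within the data shown here, compound 3 is thus the only member with a numbered value; the other two values are limits. Among the measured compounds shown here, the single measured step, a step that the two limits leave unreadable from compound 1 to compound 2, is unreadable because of the limit of > 50000 nM in this assay, at which 2 of the 3 values shown sit, and it concerns the carbonyl carbon, not the amide nitrogen.

Compound 4 `CCn1cc(C(CC)(CC)c2ccc(C#CC(O)(CC)CC)c(C)c2)cc1C(=O)N[C@@H](C)CO` differs from compound 3 by 1-(hydroxymethyl)ethyl in place of 2-(diethylamino)ethyl on an amide-type nitrogen. For the measured compounds named here, no measured step touches this position, so there is no basis for expecting a step beyond the scatter in either direction; the estimate rests on compound 3 alone and carries a wide range. In this assay compound 4 is expected to give 7000 nM, with a range from 2000 nM to 25000 nM. The expected step is a 1.3-fold higher number from compound 3 to compound 4 (0.12 log units; within the scatter).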

Compound 4, half-maximal inhibitory concentration: 6050 nM
The estimate for compound 4 lay 1.2-fold (0.06 log units) above the measured number; measured number inside the range.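

In this assay, among these compounds, the amide-type nitrogen has its only readable step, a 1.1-fold higher number from compound 3 to compound 4 (0.05 log units; within the scatter), with 1-(hydroxymethyl)ethyl in place of 2-(diethylamino)ethyl. For this pair, exchanging 2-(diethylamino)ethyl, with 0 hydrogen-bond donors, for a group with 1 hydrogen-bond donor and 1 defined stereocentre leaves the read-out within the scatter. Nothing measured here gives a cause for this outcome.

The compounds shown leave open whether a primary amine, a carboxylic acid or a longer carbon chain on this amide-type nitrogen would give a step beyond the scatter. Also open, from the compounds shown here alone, is whether the mirror-image form of 1-(hydroxymethyl)ethyl would read the same as compound 4.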